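Compound 1 and the Step to Compound 3

The compounds below may be only part of what the source reports. "The series", "measured", "known", "first", "only" and "open" are said of these compounds alone.

In a functional assay on SMMC-7721 cells (Homo sapiens) for antiproliferative activity, read by MTT assay, with a stated time of 48 h (a higher number here means a weaker inhibitor, a lower number a stronger inhibitor), compound 1 (`Cn1cc(C2=C(c3nn(CCCn4cccc4)c4ncccc34)C(=O)NC2=O)c2ccccc21`) reaches only a limit, > 100000 nM and not a number. The record for compound 1 is the limit of > 100000 nM in this assay, at which 1 of the 2 values shown sits, and nothing firmer. Compound 2 (`Cn1cc(C2=C(c3nn(CCCN4CCCCC4)c4ncccc34)C(=O)N(c3cccc4ccccc34)C2=O)c2ccccc21`) gives 220 nM as a true number in this assay. Compound 3 (`Cn1cc(C2=C(c3nn(CCn4ccnc4)c4ncccc34)C(=O)NC2=O)c2ccccc21`) departs from compound 1 at one place, 1H-imidazol-1-yl in place of (1H-pyrrol-1-yl)methyl on a saturated chain carbon, two bonds along the chain from an aromatic nitrogen on a saturated chain carbon, two bonds along the chain from an aromatic nitrogen. The same difference reads as 3-(1H-pyrrol-1-yl)propyl to 2-(1H-imidazol-1-yl)ethyl, and the rest of compound 1 stays as it is. Going by the values given here, no measured pair shows a change of this kind, so the size of the step is a judgement. With compound 1 at the limit of > 100000 nM as its only anchor, a large gain in this assay is not expected, only a modest move towards stronger inhibition or none beyond the scatter. The expected step is an at least 1.4-fold lower number from compound 1 to compound 3 (0.15 log units; that floor lies within the scatter) and it may not separate from the limit. Compound 3 is estimated at 70000 nM with an expected range from 20000 nM to 200000 nM. A limit in place of a number would be no surprise.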

Compound 3, half-maximal inhibitory concentration: > 100000 nM
Compound 3 was reported as a limit; the forecaster's own chance of this, stated with the estimate: 55%; middle value at least 1.4-fold (0.15 log units) from the limit.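

In this assay compound 3 gives > 100000 nM as a limit and not a number. Compound 1 also stands only at a limit, so no step can be read between compound 1 and compound 3, and the record holds only this: the limit of > 100000 nM in this assay, at which 2 of the 3 values shown sit.

The compounds shown leave open whether 1H-imidazol-1-yl in place of (1H-pyrrol-1-yl)methyl changes the inhibition at all.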